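This account rests on a few compounds, and the source may have more. Where it says the series, first, only, none or still open, it means among the compounds named here.

Compound 1 `CCCCNc1ccc([N+](=O)[O-])cc1S(=O)(=O)N(C)C` gives 15.2% in an assay on HEK293 cells for inhibition of solute carrier family 12 member 2 (Homo sapiens), read by fluorescence, with a stated time of 30 min, tested at 100 uM; on this read-out higher numbers stand for a stronger effect at the one concentration tested and lower numbers for a weaker effect. Compound 2 `CCCCCCNc1ccc([N+](=O)[O-])cc1S(=O)(=O)N(C)C` gives 4.9% in this assay, so that a number 10.3 percentage points lower from compound 1 to compound 2 (beyond the scatter) after (ethyl in place of hydrogen on a saturated chain carbon, four bonds along the chain from a nitrogen on an aromatic ring). Compound 3 `CCCCCCNc1ccc(C(=O)O)cc1S(N)(=O)=O` gives 4.9% in this assay, level with compound 2; the difference between the core of compound 3 and the core of compound 1 is not broken down here. Compound 4 `CCCCCCCCNc1ccc(C(=O)O)cc1S(N)(=O)=O` has not been measured; it differs from compound 3 by ethyl in place of hydrogen on a saturated chain carbon, six bonds along the chain from a nitrogen on an aromatic ring, the same kind of change as that from compound 1 to compound 2, set six rather than four bonds along the chain from the ring nitrogen. Since compound 3 already stands at 4.9%, little room for a drop remains, so a smaller step, a number 2.9 percentage points lower from compound 3 to compound 4 (within the scatter), is expected. Compound 4 is estimated at 2% in this assay, between -8% and 12%.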

Compound 4, a percentage reported as inhibition, at one concentration (the size of the read-out at that concentration, not a potency): 24%
The estimate for compound 4 lay 22 percentage points below the measured number, and the stated range ends below it.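

Ethyl in place of hydrogen on the saturated chain gave a number 19.1 percentage points higher from compound 3 to compound 4 (beyond the scatter) in this assay, so the change did not carry the same result from one core to the other: the same change on two cores in this assay, a number 10.3 percentage points lower (beyond the scatter) from compound 1 to compound 2 and a number 19.1 percentage points higher (beyond the scatter) from compound 3 to compound 4, 29.4 percentage points apart, beyond the scatter of two such steps. The two steps also sit at different places, four and six bonds along the chain from the ring nitrogen, so the contrast cannot be assigned to the core alone. Each step is also a single pair read at one concentration, which shows no general rule for the series and gives no potency.

The compounds shown leave open whether a still longer chain on the core of compound 3 would raise the number further. They also leave open how an amine in place of the carboxylic acid would read on that core.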